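The source may hold more compounds than are shown below. What is called first, only, known or untested is meant among the compounds shown, and "the series" means these compounds.

Three compounds of the series have been run in a functional assay on HOP-62 cells (Homo sapiens) for cytotoxicity, read by sulforhodamine B assay, with a stated time of 48 h; on this read-out lower numbers stand for stronger inhibition of growth and higher numbers for weaker inhibition of growth. Compound 1 `ClCc1ccccc1Cn1cnc2c(Cl)nc(Cl)nc21` gives 2040 nM in this assay. Compound 2 `ClCc1ccccc1Cn1cnc2c(Cl)ncnc21` differs from compound 1 in one place; in this assay compound 2 gives 2510 nM. Compound 3 `ClCc1cccc(Cn2cnc3c(Cl)ncnc32)c1` gives 2630 nM in this assay; it is built from the same atoms as compound 2, joined differently, and the difference between the two cores is not broken down here. Compound 3 and compound 2 lie within the scatter of each other, as do compound 3 and compound 1.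

Going by the values given here, the one counted step among the measured compounds is chloro in place of hydrogen on an aromatic carbon. It brought a 1.2-fold lower number from compound 2 to compound 1 (0.09 log units; within the scatter).

Compound 4 `ClCc1cccc(Cn2cnc3c(Cl)nc(Cl)nc32)c1` has not yet been measured. It stands to compound 3 as compound 1 stands to compound 2: chloro in place of hydrogen on an aromatic carbon. The description of where the group enters reads the same, word for word, in both pairs, so this is taken as the same change made on the other core. The change occurs twice among the compounds shown, and only the first instance has a measurement behind it.

From compound 3 to compound 4 the expected step is a 1.2-fold lower number from compound 3 to compound 4 (0.08 log units; within the scatter), about the size of the step that the same change gave as a 1.2-fold lower number from compound 2 to compound 1 (0.09 log units; within the scatter); the expectation rests on that single earlier step and on nothing else. For compound 4 the estimate in this assay is 2200 nM, with a likely range from 1200 nM to 4200 nM.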

Compound 4, concentration for 50% growth inhibition: 2290 nM
The estimate for compound 4 lay 1.0-fold (0.02 log units) below the measured number; the measured number falls inside the stated range.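

In this assay, chloro in place of hydrogen on an aromatic carbon, between two ring nitrogen atoms, now has a reading on a second core: a 1.1-fold lower number from compound 3 to compound 4 (0.06 log units; within the scatter). Set beside the earlier instance, the two steps do not differ: the same change on two cores in this assay, a 1.2-fold lower number (0.09 log units; within the scatter) from compound 2 to compound 1 and a 1.1-fold lower number (0.06 log units; within the scatter) from compound 3 to compound 4, 1.1-fold (0.03 log units) apart, within the scatter of two such steps. What carries over between these two cores is therefore a step too small to read, and the pairs show neither a real effect of the chloro group on either core nor how the change would behave on any further core.

The compounds shown hold only hydrogen or chloro at this ring carbon, so it remains open whether an amine, a methoxy group or a longer chain there would give a step beyond the scatter in this assay. Going by these compounds alone, also open is what the chloromethyl group contributes to the growth inhibition, since no compound here replaces it with a group such as methyl or hydroxymethyl.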